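The source may hold more compounds than are shown below. What is called first, only, known or untested is meant among the compounds shown, and "the series" means these compounds.

Measured in an assay on HepG2 cells for activation of nuclear factor erythroid 2-related factor 2 (Homo sapiens), read by a luciferase reporter, with a stated time of 5 h; a higher number here means that more compound is needed for the effect, a lower number that less compound is needed:
compound 1 `Cc1ccc(/C=C/c2cccc(F)c2)cc1`, 800 nM
compound 2 `Cc1ccc(/C=C/c2ccc(F)c(F)c2)cc1`, 2600 nM
compound 3 `Fc1ccc(/C=C/c2ccccc2F)cc1`, 3600 nM

Compound 3 carries the highest number of the three; its gap to compound 2 lies within the scatter, its gap to compound 1 beyond it. The difference between the cores of compound 1 and compound 3 is not broken down here.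

Compound 4 `Fc1ccc(/C=C/c2ccccc2F)c(F)c1` is not yet measured in this assay. It comes from compound 3 by fluoro in place of hydrogen on an aromatic carbon. The same kind of change, (fluoro in place of hydrogen on an aromatic carbon), gave a 3.3-fold higher number from compound 1 to compound 2 (0.51 log units; beyond the scatter). The surroundings are not the same: in compound 2 the entering fluoro sits ortho to a fluoro group and para to a group of 9 heavy atoms, in compound 4 ortho to a group of 9 heavy atoms and meta to a fluoro group.

Compound 4 is expected to give 7000 nM in this assay, between 3000 nM and 18000 nM. This means an expected step of a 1.9-fold higher number from compound 3 to compound 4 (0.29 log units; within the scatter), resting on compound 2 having risen from compound 1 by a 3.3-fold higher number from compound 1 to compound 2 (0.51 log units; beyond the scatter); since the place differs, a somewhat smaller step is assumed.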

Compound 4, half-maximal effective concentration: 9600 nM
The estimate for compound 4 lay 1.4-fold (0.14 log units) below the measured number; the measured number falls inside the stated range.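

In this assay the new step is a 2.7-fold higher number from compound 3 to compound 4 (0.43 log units; beyond the scatter) and, as on the core of compound 1, fluoro in place of hydrogen on an aromatic carbon moves the number up. The change carries over to the second core at a similar size, although the entering fluoro stands in a different place on each: the same change on two cores in this assay, a 3.3-fold higher number (0.51 log units; beyond the scatter) from compound 1 to compound 2 and a 2.7-fold higher number (0.43 log units; beyond the scatter) from compound 3 to compound 4, 1.2-fold (0.09 log units) apart, within the scatter of two such steps. This rests on two pairs only, so it does not separate the place from the core and says nothing about a third core.

Still open, on these data alone, is whether chloro, methoxy or an amine in the same place would move the number in the same direction. Also open, as far as these compounds go, is whether a further fluoro would add another step of this size.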